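The compounds below may be only part of what the source reports. "The series", "measured", "known", "first", "only" and "open" are said of these compounds alone.

Measured in a functional assay on UACC-62 cells (Homo sapiens) for cytotoxicity, read by MTT assay, with a stated time of 6 days; on this read-out lower numbers stand for stronger inhibition and higher numbers for weaker inhibition:
- compound 1 `CC(=O)N[C@@H](CSC(=O)Nc1cccc(Cl)c1)C(=O)O`: > 200000 nM (a limit)
- compound 2 `CC(=O)N[C@@H](CSC(=O)Nc1ccccc1)C(=O)O`: 125000 nM

Not yet measured: compound 3 `CC(=O)N[C@@H](CSC(=O)Nc1cc(Cl)cc(Cl)c1)C(=O)O`.

For compound 1, this assay gives a limit and not a number: > 200000 nM. Compound 3 differs from compound 1 by chloro in place of hydrogen on an aromatic carbon. For the measured compounds named here, the one measured step that bears on this is the reverse kind of change, an at least 1.6-fold lower number from compound 1 to compound 2 (0.20 log units; that floor lies within the scatter). Going by the values given here, with only that step as a guide, no change beyond the scatter is expected, and a further limit is possible. The expected result is an at least 1.2-fold lower number from compound 1 to compound 3 (0.09 log units; that floor lies within the scatter). Compound 3 is estimated at 160000 nM, with an expected range of 70000 nM to 300000 nM.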

Compound 3, half-maximal inhibitory concentration: > 200000 nM
Compound 3: a limit, no number; the forecaster's own chance of this, stated with the estimate: 45%; middle value at least 1.2-fold (0.09 log units) from the limit.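

In this assay compound 1 and compound 3 both end in a limit, so no step between them can be read: the limit of > 200000 nM in this assay, at which 2 of the 3 values shown sit.

Still open, going by these compounds, is whether chloro in place of hydrogen on an aromatic carbon separates compound 3 from compound 1 at all.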